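The source may report more compounds than this note shows. Statements on the series, on what has been measured and on what is new or still open speak of the compounds shown alone.

Measured in a functional assay on SK-OV-3 cells (Homo sapiens) for antiproliferative activity, read by MTT assay, with a stated time of 24 h; a higher number here means a weaker inhibitor, a lower number a stronger inhibitor:
Compound 1 `COc1ccc(/C=C/C(=O)c2ccc(OC)c3c2OC(C)(C)C=C3)cn1`: > 10000 nM (a limit of the assay, not a number)
Compound 2 `COc1ccc(C(=O)/C=C/c2cccc(C(F)(F)F)c2)c2c1C=CC(C)(C)O2`: 9330 nM
Compound 3 `COc1ccc(C(=O)/C=C/c2ccc(Cl)c(Cl)c2)c2c1C=CC(C)(C)O2`: 9940 nM

Compound 3, at 9940 nM, lies within the scatter of compound 2, at 9330 nM. Compound 1 is reported only as a limit, (the limit of > 10000 nM in this assay, at which 1 of the 3 values shown sits). Compound 4 `COc1ccc(C(=O)/C=C/c2cccc(O)c2)c2c1C=CC(C)(C)O2` carries 3-hydroxyphenyl in place of 3,4-dichlorophenyl on a double-bonded chain carbon bound to a double-bonded chain carbon. One measured step changes the group at this place: a number no higher from compound 1 to compound 3 (the limit leaves the size open). Its size cannot be read, so it sets a direction for that pair alone and gives no size to carry over. The two numbers in this assay sit close together, and compound 3 at 9940 nM is the natural starting point. No shift beyond the scatter is therefore expected, though the new group has not been tested in this series. The estimated change is a 1.1-fold lower number from compound 3 to compound 4 (0.04 log units; within the scatter), which stays within the scatter. For compound 4 the expected value is 9000 nM, with an estimated range of 3500 nM to 20000 nM.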

Compound 4, half-maximal inhibitory concentration: > 10000 nM
Compound 4 ended at the assay's limit (the forecaster's own chance of this, stated with the estimate: 30%); at least 1.1-fold (0.04 log units) between middle value and limit.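

In this assay compound 4 gives > 10000 nM, which is a limit and not a number. 3-hydroxyphenyl in place of 3,4-dichlorophenyl on a double-bonded chain carbon bound to a double-bonded chain carbon gives a number no lower from compound 3 to compound 4 (the limit leaves the size open). Hydroxy in place of trifluoromethyl on an aromatic carbon gives an at least 1.0-fold higher number from compound 2 to compound 4 (0.03 log units; that floor lies within the scatter), which shows no loss beyond the scatter and leaves the true size of the step open, while the step to compound 4 from compound 1 cannot be read. With this result, the series rests increasingly on a limit rather than on numbers: the limit of > 10000 nM in this assay, at which 2 of the 4 values shown sit.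

The compounds shown leave open whether any group at this place can move the value clearly beyond the scatter. An amine or a carboxylic acid on the aromatic ring in place of the hydroxy group would be one such test.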